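A few compounds are considered here, and "the series" means these few. Any claim that something is new, unique, unknown or untested is made for them only; others in the source may bear on it.

Of the compounds shown here, two of the same core have so far been tested in a functional assay on MDA-MB-231 cells (Homo sapiens) for inhibition, read by MTT assay, with a stated time of 72 h; a lower number here means a stronger inhibitor, a higher number a weaker inhibitor. Compound 1 `O=C(CSc1nc(Nc2ccccc2)c2ccccc2n1)Nc1ccccc1Cl` gives 24400 nM in this assay, and compound 2 `O=C(CSc1nc(Nc2ccccc2)c2ccccc2n1)Nc1ccc(Cl)cc1` gives 17200 nM. Among the compounds with values here, the one step measured between them, a 1.4-fold lower number from compound 1 to compound 2 (0.15 log units; within the scatter), lies within the scatter, so the two numbers cannot be told apart on this evidence, and compound 2 is simply one of two compounds at similar level.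

Compound 3 `O=C(CSc1nc(Nc2ccccc2)c2ccccc2n1)Nc1ccc(F)c(Cl)c1` is the next compound, not yet measured. It differs from compound 2 in one place: 3-chloro-4-fluorophenyl in place of 4-chlorophenyl on an amide-type nitrogen. Within the data shown here, the only measured step that bears on this change is the move of chlorine on the same amide-type nitrogen from compound 1 to compound 2, which, as a 1.4-fold lower number from compound 1 to compound 2 (0.15 log units; within the scatter) shows, stayed within the scatter. Adding a fluorine to that ring has not been tested at all, so there is nothing to point either way. The expectation for compound 3 in this assay is therefore a step no larger than the scatter, a 1.1-fold lower number from compound 2 to compound 3 (0.03 log units; within the scatter). Compound 3 is estimated at 16000 nM, with a range from 6000 nM to 45000 nM.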

Compound 3, half-maximal inhibitory concentration: 21600 nM
The estimate for compound 3 lay 1.4-fold (0.13 log units) below the measured number; the range from low to high includes it.
By their numbers in this assay, from the lowest: compounds 2, 3 and 1 (each within the scatter of the next).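

In this assay, putting 3-chloro-4-fluorophenyl in place of 4-chlorophenyl on the amide-type nitrogen gives a 1.3-fold higher number from compound 2 to compound 3 (0.10 log units; within the scatter) and so does not move the number beyond what repeat measurements would produce. Against the third compound, the change to 3-chloro-4-fluorophenyl from 2-chlorophenyl gives a 1.1-fold lower number from compound 1 to compound 3 (0.05 log units; within the scatter) and also stays inside that limit, so all three halogen-bearing phenyl groups now sit at a similar level and cannot be ranked. What is new is that a second halogen on this ring, and not only a shift of the single chlorine, leaves the result indistinguishable in this cell assay, although no measurement here offers any explanation for this.

The compounds shown carry only chlorine and fluorine on this ring, so they leave open whether a different kind of group there, such as a methoxy group, an amine or a carboxylic acid, would produce a step beyond the scatter. They also leave open what a longer chain linking the amide to the shared core would do, and whether changes elsewhere on that core matter more than changes on this ring.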